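Replacing Chloro With Butyl on a Cinnamamide Anilide

The compounds below may be only part of what the source reports. "The series", "measured", "known", "first", "only" and "open" are said of these compounds alone.

Measured compounds:
compound 1 `CCCc1cc(N)c2cc(NC(=O)/C=C/c3ccc(Cl)cc3)ccc2n1`: 6 nM
compound 2 `Cc1cc(N)c2cc(NC(=O)/C=C/c3ccc(C(F)(F)F)cc3)ccc2n1`: 8 nM
compound 3 `CCCc1cc(N)c2cc(NC(=O)c3ccc(C(F)(F)F)cc3)ccc2n1`: 10000 nM

In an assay on isolated protein for displacement of a labelled ligand from melanin-concentrating hormone receptor 1 (Homo sapiens) (a lower number here means a stronger inhibitor, a higher number a weaker inhibitor), compound 1 gives the lowest of the three numbers. Compound 2 lies within the usual scatter of compound 1, so the two cannot be ranked, while compound 3 stands far beyond that scatter with a much weaker result. Compound 4 `CCCCc1ccc(/C=C/C(=O)Nc2ccc3nc(CCC)cc(N)c3c2)cc1` differs from compound 1 in one place: butyl in place of chloro on an aromatic carbon. Among the compounds with values here, no measured pair shows this change, so the outlook rests only on compound 1 and compound 2, whose small groups at that place both give strong binding. A modest step toward a higher number is expected, a 5.0-fold higher number from compound 1 to compound 4 (0.70 log units; beyond the scatter). Compound 4 is estimated at 30 nM, with an expected range from 6 nM to 150 nM.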

Compound 4, half-maximal inhibitory concentration: 45 nM
Estimate against measurement, compound 4: 1.5-fold (0.18 log units) below; measured number inside the range.
By their numbers in this assay, from the lowest: compounds 1 and 2 (each within the scatter of the next); then compound 4; then compound 3.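

Compound 4 brings the first long chain to this place on the aromatic ring, and in this assay swapping chloro for butyl gives a 7.5-fold higher number from compound 1 to compound 4 (0.88 log units; beyond the scatter). The step is modest, so this place accepts a chain of four carbons, and compound 4 still binds at 45 nM. Nothing measured here explains the step.

The compounds shown leave open how binding changes with a shorter ethyl chain or a longer hexyl chain at this place. They also leave open what an amine or a carboxylic acid would do there.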